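The source may hold more compounds than are shown below. What is called first, only, known or untested is meant among the compounds shown, and "the series" means these compounds.

Working notes on the series.

For the measured compounds named here, compound 1 `N=C(N)Nc1nc(N)nc2c1ncn2CCN` is the first entry. In a functional assay on MCF7 cells (Homo sapiens) for inhibition, read by fluorescence, with a stated time of 72 h (on this read-out lower numbers stand for stronger inhibition and higher numbers for weaker inhibition), compound 1 gives only a limit, > 100000 nM, and no number. Compound 2 `CC[C@H](CO)Nc1nc(NC(=N)N)c2ncn(C(C)C)c2n1` is the second entry. In this assay compound 2 gives 4500 nM. Compound 2 therefore holds the only number shown here; the other value is a limit, (the limit of > 100000 nM in this assay, at which 1 of the 2 values shown sits), so no measured step between two numbers exists in this set and nothing can yet be said about the size of any change within it.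

Compound 3 `CC(C)n1cnc2c(NC(=N)N)nc(N3CCC[C@H]3CO)nc21` is not yet measured. It differs from compound 2 in one place: 2-(hydroxymethyl)pyrrolidin-1-yl in place of (1-(hydroxymethyl)propyl)amino on an aromatic carbon. Going by the values given here, no measured pair with a comparable change stands, so the direction and size of the step rest on expectation alone. A modest loss of potency in this assay is expected, larger than the usual scatter, but not reaching the limit of the assay.

For compound 3 the expected value in this assay is 9000 nM, with a range from 2500 nM to 35000 nM. The expected step is a 2.0-fold higher number from compound 2 to compound 3 (0.30 log units; within the scatter).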

Compound 3, half-maximal inhibitory concentration: 6200 nM
Beside the measured number, compound 3's estimate is 1.5-fold (0.16 log units) above it, within the range that was stated.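

For the compounds shown here, at the aromatic carbon between two ring nitrogen atoms, 2-(hydroxymethyl)pyrrolidin-1-yl in place of (1-(hydroxymethyl)propyl)amino gives in this assay a 1.4-fold higher number from compound 2 to compound 3 (0.14 log units; within the scatter) as the first step between two numbers. Compound 2 and compound 3 therefore cannot be told apart on this read-out, even though the entering group brings a five-membered non-aromatic ring and carries 1 hydrogen-bond donor where the leaving group carries 2, so this position takes this particular swap without a difference beyond the scatter. Nothing measured on the compounds shown accounts for this result.

On these data alone, it remains open how a longer chain, a morpholine ring, a carboxylic acid or a plain amine on this same carbon would read in this assay and whether the hydroxymethyl arm of either group matters at all. Going by these compounds alone, compound 1 gives only a limit and differs from the other two compounds in more than one place, so no step involving it can be read.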